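Moving the methyl along the phenyl on the triazole

The source may report more compounds than this note shows. Statements on the series, on what has been measured and on what is new or still open speak of the compounds shown alone.

compound 1 `N#CC1=C(N)Oc2c(c3nc4ccccc4nc3c3ccccc23)C12C(=O)N(Cc1cnnn1-c1cccc(Br)c1)c1ccccc12` gives a limit in an ADME assay on L02 cells (Homo sapiens) for antiproliferative activity, read by MTT assay, with a stated time of 48 h; a higher number here means a weaker inhibitor, a lower number a stronger inhibitor: > 50000 nM.
compound 2 `N#CC1=C(N)Oc2c(c3nc4ccccc4nc3c3ccccc23)C12C(=O)N(Cc1cnnn1-c1ccc([N+](=O)[O-])cc1)c1ccccc12` gives a limit in this assay: > 50000 nM.
compound 3 `Cc1ccccc1-n1nncc1CN1C(=O)C2(C(C#N)=C(N)Oc3c(N)cc4nc5ccccc5nc4c32)c2ccccc21` gives a limit in this assay: > 50000 nM.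

Compound 3 stands where every measured compound stands, namely at the limit of > 50000 nM in this assay, at which 3 of the 3 values shown sit; its value is a limit and not a number. Going by the values given here, the one measured step, a step that the two limits leave unreadable from compound 1 to compound 2, joins two limits and therefore cannot be read for size or direction, so nothing measured here shows how any change on the phenyl attached to the triazole moves this assay.

Compound 4 `Cc1cccc(-n2nncc2CN2C(=O)C3(C(C#N)=C(N)Oc4c(N)cc5nc6ccccc6nc5c43)c3ccccc32)c1` is obtained from compound 3 by the change (3-methylphenyl in place of 2-methylphenyl on an aromatic nitrogen). No measured step concerns a methyl shifted along that phenyl; the only step shown, from a bromophenyl to a nitrophenyl, is unreadable. With compound 3 at the limit and all three values at the same limit, compound 4 is expected to return a limit as well, which would mean a step of a number no higher from compound 3 to compound 4 (the limit leaves the size open) that is not beyond the scatter. The estimate for compound 4 in this assay is therefore 50000 nM, within 20000 nM to 120000 nM.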

Compound 4, half-maximal inhibitory concentration: > 50000 nM
Compound 4 gave a limit, no number; the forecaster's own chance of this, stated with the estimate: 85%; the middle value lies on the limit itself.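

The shift of the methyl from compound 3 to compound 4 joins two limits, so no step can be read between them, for size or direction. All the compounds shown now sit together: the limit of > 50000 nM in this assay, at which 4 of the 4 values shown sit. Still open is whether any change on the phenyl attached to the triazole moves this assay at all, since none of these compounds has given a number.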